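The source may hold more compounds than are shown below. What is called first, only, known or untested is meant among the compounds shown, and "the series" means these compounds.

Measured in a functional assay on SK-MEL-2 cells (Homo sapiens) for cytotoxicity, read by sulforhodamine B assay, with a stated time of 48 h; a higher number here means that more compound is tolerated, a lower number that less compound is tolerated:
Compound 1 `ClCc1ccccc1Cn1cnc2c(Cl)nc(Cl)nc21`: 8510 nM
Compound 2 `ClCc1cccc(Cn2cnc3c(Cl)nc(Cl)nc32)c1`: 10000 nM
Compound 3 `Nc1nc(Cl)c2ncn(Cc3ccccc3CCl)c2n1`: a limit of the assay, > 100000 nM

Compounds 1 and 2 are built from the same atoms joined differently; the difference between their two cores is not broken down here. In this assay compound 2 gives a number close to that of compound 1, within the usual scatter of the assay. Compound 3 differs from compound 1 by a single change, (amino in place of chloro on an aromatic carbon), and this change produced an at least 11-fold higher number from compound 1 to compound 3 (1.07 log units; beyond the scatter). That step is only a lower bound because of the limit of > 100000 nM in this assay, at which 1 of the 3 values shown sits.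

Compound 4 `Nc1nc(Cl)c2ncn(Cc3cccc(CCl)c3)c2n1` has not yet been measured. It differs from compound 2 by amino in place of chloro on an aromatic carbon, the same change at the same place as between compound 1 and compound 3. For compound 4 the expected step is a 15-fold higher number from compound 2 to compound 4 (1.18 log units; beyond the scatter), resting on an at least 11-fold higher number from compound 1 to compound 3 (1.07 log units; beyond the scatter) and on compound 2 standing at 10000 nM. Compound 4 is therefore estimated to sit near 150000 nM, between 50000 nM and 500000 nM, and may well come back as a limit of the assay rather than a number.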

Compound 4, concentration lethal to 50% of the cells: > 100000 nM
Compound 4: no number, only a limit (the forecaster's own chance of this, stated with the estimate: 75%); the middle value does not contradict the limit.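

In this assay, amino in place of chloro on an aromatic carbon gives an at least 10-fold higher number from compound 2 to compound 4 (1.00 log units; beyond the scatter), so the change moves the number the same way on this core as on the core of compound 1. Compound 4 gives > 100000 nM, which is a limit of the assay and not a number. The result shows that the direction carries from one core to the other, but it does not show the true size of either step or whether the two cores respond equally: the same change on two cores in this assay, an at least 11-fold higher number (1.07 log units; beyond the scatter) from compound 1 to compound 3 and an at least 10-fold higher number (1.00 log units; beyond the scatter) from compound 2 to compound 4; the limit leaves it open whether they differ

Still open, going by these compounds, is how far above the tested range the two amino compounds lie, and part of the series now gives no exact number: the limit of > 100000 nM in this assay, at which 2 of the 4 values shown sit. Also open is whether another group on the same carbon, such as a methoxy group or a dimethylamino group, would give a measurable number and so allow the two cores to be compared by size as well as by direction.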